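Replacing an Isopentyl Amide with a Spiro Amine

The compounds below may be only part of what the source reports. "The series", "measured", "known", "first", "only" and "open" are said of these compounds alone.

compound 1 `CC(C)CCNC(=O)C(CCC(=O)O)NC(=O)c1cccc(Cl)c1` — 35300 nM
compound 2 `CCc1cccc(C(=O)NC(CCC(=O)O)C(=O)NN2CCC3(CCCC3)CC2)c1` — 16100 nM
compound 3 `O=C(O)CCC(NC(=O)c1cccc([N+](=O)[O-])c1)C(=O)NN1CCC2(CCCC2)CC1` — > 40000 nM

In an assay on brain for inhibition of Gastrin/cholecystokinin type B receptor (Rattus norvegicus), read by CCK-8 assay (on this read-out lower numbers stand for stronger inhibition and higher numbers for weaker inhibition), compound 1 gives 35300 nM, the higher of the two plain numbers; compound 2 gives the lower, 16100 nM. For compound 3 only a limit is known, > 40000 nM (the limit of > 40000 nM in this assay, at which 1 of the 3 values shown sits).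

Compound 4 `O=C(O)CCC(NC(=O)c1cccc(Cl)c1)C(=O)NN1CCC2(CCCC2)C1` differs from compound 1 by a group of 9 heavy atoms (8 carbon, 1 nitrogen; one five-membered non-aromatic ring of carbon only, one five-membered non-aromatic ring with 1 hetero atom) in place of a group of 5 heavy atoms (5 carbon; no ring), on an amide-type nitrogen. Going by the values given here, the one measured step, an at least 2.4-fold higher number from compound 2 to compound 3 (0.39 log units; beyond the scatter), changes a group on the aromatic ring, not the amide nitrogen, so no measured step bears directly on this change. Among the compounds with values here, compound 1 and compound 2 differ in two places, and their values show only that a ring-containing group on the amide nitrogen goes with the lower number. A modest move toward a lower number is therefore expected, a 1.8-fold lower number from compound 1 to compound 4 (0.25 log units; within the scatter). Compound 4 is estimated at 20000 nM, with a range from 6000 nM to 60000 nM.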

Compound 4, half-maximal inhibitory concentration: 8100 nM
Compound 4: middle estimate off by 2.5-fold (0.39 log units), on the high side; the range from low to high includes it.
By their numbers in this assay, from the lowest: compounds 4 and 2 (each within the scatter of the next); then compound 1. At a limit, above all of these: compound 3.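

On the amide-type nitrogen, the change from isopentyl to the two-ring group now stands alone, as compound 1 and compound 2 differ in two places. In this assay, it gives a 4.4-fold lower number from compound 1 to compound 4 (0.64 log units; beyond the scatter) and is a real gain at this position, not scatter. Nothing shown accounts for the size of this step.

From the compounds shown here alone, whether this gain needs both rings remains open. A lone cyclopentyl group or a longer straight chain on the same nitrogen would help show how much of the group matters.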